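A few compounds are considered here, and "the series" means these few. Any claim that something is new, unique, unknown or untested is made for them only; others in the source may bear on it.

Compound 1 `O=C(Nc1ccccc1C(F)(F)F)C1CCc2ccccc2N1` is the unsubstituted member of the series. In a functional assay on ACHN cells (Homo sapiens) for cytotoxicity, read by sulforhodamine B assay, with a stated time of 72 h (a higher number here means a weaker inhibitor of growth, a lower number a stronger inhibitor of growth), compound 1 gives 57600 nM. Compound 2 `O=C(Nc1ccccc1C(F)(F)F)C1CCc2ccccc2N1C(=O)c1ccccc1` differs from compound 1 by benzoyl in place of hydrogen on a nitrogen on an aromatic ring in a ring; this change made a 7.1-fold lower number from compound 1 to compound 2 (0.85 log units; beyond the scatter). Compound 3 `O=C(Nc1cc(C(F)(F)F)cc(C(F)(F)F)c1)C1CCc2ccccc2N1` carries a different core; the difference between the two cores is not broken down here. In this assay compound 3 gives 8190 nM, and compound 2 gives 8090 nM; these two values lie within the scatter of each other, so no order is drawn between them. Compound 4 `O=C(Nc1cc(C(F)(F)F)cc(C(F)(F)F)c1)C1CCc2ccccc2N1C(=O)c1ccccc1` is not yet measured. It differs from compound 3 by benzoyl in place of hydrogen on a nitrogen on an aromatic ring in a ring; the place reads the same word for word as in the change from compound 1 to compound 2, so this is the same change, occurring twice among the compounds shown. For compound 4 a step of a 3.7-fold lower number from compound 3 to compound 4 (0.57 log units; beyond the scatter) in this assay is expected. Among the compounds with values here, this rests on the single precedent, a 7.1-fold lower number from compound 1 to compound 2 (0.85 log units; beyond the scatter), taken as somewhat smaller here because compound 3 already starts from 8190 nM. The estimate for compound 4 in this assay is 2200 nM, with a range from 700 nM to 6500 nM.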

Compound 4, concentration for 50% growth inhibition: 2920 nM
For compound 4 the middle estimate is 1.3-fold (0.12 log units) below the measured one, and the stated range covers the measured number.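

In this assay, benzoyl in place of hydrogen on a nitrogen on an aromatic ring in a ring again gives a step beyond the scatter, a 2.8-fold lower number from compound 3 to compound 4 (0.45 log units; beyond the scatter), so the change lowers the number on both cores shown. As far as these four compounds can tell, the size of the step carries over from one core to the other: the same change on two cores in this assay, a 7.1-fold lower number (0.85 log units; beyond the scatter) from compound 1 to compound 2 and a 2.8-fold lower number (0.45 log units; beyond the scatter) from compound 3 to compound 4, 2.5-fold (0.40 log units) apart, within the scatter of two such steps

This does not show that the step is constant, since it rests on two pairs in a single cell line, and it says nothing about how benzoyl acts or about any core beyond these two.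

Among the compounds shown, benzoyl is the only group on this nitrogen, so it remains open whether acetyl, a longer acyl chain or a benzoyl ring bearing an amine or a carboxylic acid would give a step of similar size. As far as these compounds go, it also remains open whether the lower number depends on the aromatic ring of the benzoyl group or on the carbonyl alone.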